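A few compounds are considered here, and "the series" means these few. Any claim that something is new, unique, unknown or untested is made for them only; others in the source may bear on it.

In a functional assay on OVCAR-3 cells (Homo sapiens) for antiproliferative activity, read by spectrophotometry, with a stated time of 2 days (a higher number here means a weaker inhibitor of growth, a lower number a stronger inhibitor of growth), compound 2 `Cc1ccc(Nc2ncc(C(F)(F)F)c(N3Cc4cccc(N(C)S(C)(=O)=O)c4C3)n2)c(Cl)c1` returns only the assay limit, > 30000 nM, so no number is known for it. Compound 1 `Cc1ccc(Nc2ncc(C(F)(F)F)c(N3Cc4cccc(N(C)S(C)(=O)=O)c4C3)n2)cc1C` likewise rests at the limit, > 30000 nM. Compound 3 `COc1cc(Nc2ncc(C(F)(F)F)c(N3Cc4cccc(N(C)S(C)(=O)=O)c4C3)n2)cc(OC)c1` gives 630 nM. The step that the two limits leave unreadable from compound 1 to compound 2 cannot be read, since both values sit at the limit of > 30000 nM in this assay, at which 2 of the 3 values shown sit. Within the data shown here, the steps of an at least 47-fold lower number from compound 2 to compound 3 (1.67 log units; beyond the scatter) and an at least 47-fold lower number from compound 1 to compound 3 (1.67 log units; beyond the scatter) show that 3,5-dimethoxyphenyl is the only change so far that yields a number. Compound 4 `CN(c1cccc2c1CN(c1nc(Nc3cccc(C(F)(F)F)c3)ncc1C(F)(F)F)C2)S(C)(=O)=O` carries 3-(trifluoromethyl)phenyl in place of 2-chloro-4-methylphenyl on a nitrogen on an aromatic ring. Among the measured compounds shown here, no measured step covers 3-(trifluoromethyl)phenyl, so the expectation leans on the two limits and on the single number of compound 3. Compound 4 is therefore expected near an estimated 10000 nM (range 1000 nM to 30000 nM). The expected step is an at least 3.0-fold lower number from compound 2 to compound 4 (0.47 log units; beyond the scatter).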

Compound 4, concentration for 50% growth inhibition: > 30000 nM
Compound 4 ended at the assay's limit; the forecaster's own chance of this, stated with the estimate: 40%; at least 3.0-fold (0.47 log units) between middle value and limit.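

In this assay compound 4 gives a limit, not a number: the limit of > 30000 nM in this assay, at which 3 of the 4 values shown sit.

On this nitrogen, 3-(trifluoromethyl)phenyl in place of 3,5-dimethoxyphenyl gives an at least 47-fold higher number from compound 3 to compound 4 (1.67 log units; beyond the scatter), so among the four aryl groups shown only 3,5-dimethoxyphenyl yields a number. The steps to compound 4 from compound 1 and compound 2 cannot be read, since both ends are limits.

Open, going by these compounds, is whether a phenyl with a single methoxy group, or an aminophenyl, would also give a number in this assay. Also open, on these data alone, is which feature of 3,5-dimethoxyphenyl separates compound 3 from the others.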